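Fluoro in place of methyl on the 4-methylphenyl group

A few compounds are considered here, and "the series" means these few. Any claim that something is new, unique, unknown or untested is made for them only; others in the source may bear on it.

Values measured in a functional assay on HCT-15 cells (Homo sapiens) for antiproliferative activity, read by MTT assay, with a stated time of 72 h (a higher number here means a weaker inhibitor, a lower number a stronger inhibitor), are as follows
Compound 1 `CCCn1ccnc1-c1cc(OC)c(OC)c(OC)c1` gives > 100000 nM (a limit of the assay)
Compound 2 `COc1cc(-c2nccn2-c2ccc(C)cc2)cc(OC)c1OC` gives 800 nM (a measured number)

Among the measured compounds shown here, only compound 2 has an exact number so far. The value for compound 1 is a limit.

Compound 3 `COc1cc(-c2nccn2-c2ccc(F)cc2)cc(OC)c1OC` changes one group of compound 2 (fluoro in place of methyl on an aromatic carbon), with fluoro in place of methyl on an aromatic carbon. For the measured compounds named here, the only measured step is large (an at least 120-fold lower number from compound 1 to compound 2 (2.09 log units; beyond the scatter)), but it put 4-methylphenyl in place of propyl on an aromatic nitrogen. That step therefore says little about the methyl alone, and 4-fluorophenyl still keeps an aromatic ring on that nitrogen. With no direction favoured, the estimated step is no change at the digits printed from compound 2 to compound 3 (within the scatter) (no shift beyond the scatter is expected). Compound 3 is expected near 800 nM (estimated range from 200 nM to 3000 nM).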

Compound 3, half-maximal inhibitory concentration: 68600 nM
Estimate against measurement, compound 3: 86-fold (1.93 log units) below, outside the stated range (above it).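

In this assay, fluoro in place of methyl gives an 86-fold higher number from compound 2 to compound 3 (1.93 log units; beyond the scatter), so an aromatic ring on that nitrogen is not enough by itself, and this one methyl carries much of the activity of compound 2. Set against the propyl group, the 4-fluorophenyl group gives an at least 1.4-fold lower number from compound 1 to compound 3 (0.16 log units; that floor lies within the scatter), a floor that does not separate the two compounds. Compound 1 is known only as a limit: the limit of > 100000 nM in this assay, at which 1 of the 3 values shown sits.

As far as these compounds go, whether the large step reflects the loss of the methyl or the arrival of the fluoro stays open. A plain phenyl, a 4-chlorophenyl or a 4-ethylphenyl group on the same nitrogen would help to tell these apart, and would show whether a larger group at this place is tolerated.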